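The compounds below may be only part of what the source reports. "The series", "measured", "known", "first", "only" and "open" are said of these compounds alone.

- compound 1 `CCN(CC)CC(=O)OC1CC2(N(C)C)CC(c3ccccc3)C1C(c1ccccc1)C2`: 30100 nM
- compound 2 `CCN(CC)CC(=O)OC1CC2(N3CCCC3)CC(c3ccccc3)C1C(c1ccccc1)C2`: 49000 nM

In an ADME assay on L6 cells (Rattus norvegicus) for cytotoxicity (a lower number here means a stronger inhibitor, a higher number a weaker inhibitor), compound 2 gives 49000 nM, which lies within the scatter of compound 1, so the two numbers do not separate. The next compound to be measured is compound 3 `O=C(CN1CCCCC1)OC1CC2(N3CCCC3)CC(c3ccccc3)C1C(c1ccccc1)C2`. It keeps the pyrrolidin-1-yl group of compound 2 and carries piperidin-1-yl in place of diethylamino on a saturated chain carbon bound to a carbonyl carbon.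

Within the data shown here, only one measured step bears on this, and only indirectly: a 1.6-fold higher number from compound 1 to compound 2 (0.21 log units; within the scatter). That step replaced dimethylamino with pyrrolidin-1-yl on a saturated ring carbon, so it lies at a different place. Among the measured compounds shown here, no measured step covers a change on the chain carbon. For the measured compounds named here, with only that small step as a guide, and with compound 2 at 49000 nM as the starting point, no step beyond the scatter is expected in this assay, and no direction can be assigned with confidence. The estimate is a 1.2-fold lower number from compound 2 to compound 3 (0.09 log units; within the scatter), which is expected to remain within the scatter. For compound 3 the expected value is 40000 nM, with an estimated range of 17000 nM to 90000 nM.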

Compound 3, half-maximal inhibitory concentration: 14200 nM
The estimate for compound 3 lay 2.8-fold (0.45 log units) above the measured number; measured number outside the range, below it.
By their numbers in this assay, from the lowest: compound 3; then compounds 1 and 2 (each within the scatter of the next).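

Notes on the amine at the saturated chain carbon bound to a carbonyl carbon: in this assay, piperidin-1-yl in place of diethylamino gives a 3.5-fold lower number from compound 2 to compound 3 (0.54 log units; beyond the scatter), so this position responds to a change of amine. Among these compounds, the only earlier step, at a saturated ring carbon, gave a 1.6-fold higher number from compound 1 to compound 2 (0.21 log units; within the scatter) and did not separate its two compounds, which makes this the first change to move the number beyond the scatter. The exchange replaces an open diethylamino group with one six-membered non-aromatic ring, while the count of hydrogen-bond donors and acceptors stays the same, but nothing available accounts for the size or direction of the step.

With a single pair at this position, the step cannot be assigned to the ring itself or to the added heavy atom, and a comparison with morpholin-4-yl or pyrrolidin-1-yl on the same chain carbon would help to separate these readings. As far as these compounds go, it also remains open whether piperidin-1-yl gives a similar step when the saturated ring carbon carries dimethylamino, as in compound 1, rather than pyrrolidin-1-yl.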